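This account rests on a few compounds, and the source may have more. Where it says the series, first, only, none or still open, it means among the compounds named here.

In a functional assay on HCT-116 cells (Homo sapiens) for inhibition, read by sulforhodamine B assay, with a stated time of 48 h (on this read-out lower numbers stand for stronger inhibition and higher numbers for weaker inhibition), compound 1 (`C=CCC(O)(c1ccc(OC)c(OC)c1OC)c1cccc2ccccc12`) stands at > 20000 nM as a limit of the assay, not a number. Compound 2 (`COc1ccc(C(c2ccc(OCC(=O)O)cc2)c2cccc3ccccc23)c(OC)c1OC`) gives 5020 nM in this assay as a measured value. Compound 3 (`COc1ccc(C(O)(Cc2ccccc2)c2cccc3ccccc23)c(OC)c1OC`) differs from compound 1 in one place, with phenyl in place of vinyl on a saturated chain carbon, which also reads allyl to benzyl (phenyl in place of vinyl on a saturated chain carbon, two bonds along the chain from two aromatic carbons and an oxygen on a saturated carbon). Among the measured compounds shown here, no measured step covers this change, so only a modest gain in inhibition is expected, and the estimated step (an at least 1.6-fold lower number from compound 1 to compound 3 (0.22 log units; that floor lies within the scatter)) may still end at the limit. In this assay the estimate for compound 3 is 12000 nM (expected range 4000 nM to 30000 nM).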

Compound 3, half-maximal inhibitory concentration: > 20000 nM
Compound 3 ended at the assay's limit; the forecaster's own chance of this, stated with the estimate: 45%; middle value at least 1.6-fold (0.22 log units) from the limit.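

Compound 1 and compound 3 both end at a limit of this assay, not at a number, so no step between them can be read: the limit of > 20000 nM in this assay, at which 2 of the 3 values shown sit.

The compounds shown leave open whether the change from allyl to benzyl alters inhibition at all.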